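The compounds below may be only part of what the source reports. "The series", "measured", "known", "first", "only" and "open" are said of these compounds alone.

Measured so far in an ADME assay on Vero cells (Chlorocebus sabaeus) for cytotoxicity, read by resazurin assay, with a stated time of 3 days; on this read-out lower numbers stand for stronger inhibition and higher numbers for weaker inhibition:

Compound 1 `CCN(CC)c1cc2[nH]c(C3CCCCC3)nc2cc1NC(=O)OCC(F)(F)F` gives > 100 ug/mL, a limit of the assay.
Compound 2 `CCN(CC)c1cc2[nH]c(C3CCCCC3)nc2cc1NC(=O)c1ccc(F)cc1` gives > 100 ug/mL, a limit of the assay.
Compound 3 `CCCC(C)OC(=O)Nc1cc2nc(C3CCCCC3)[nH]c2cc1N(CC)CC` gives > 100 ug/mL, a limit of the assay.

Compound 3 therefore stands where everything in the series stands so far: at the limit of > 100 ug/mL in this assay, at which 3 of the 3 values shown sit. No value shown here is a number; all three sit at the same limit.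

The next compound, compound 4 `C=Cc1cccc(C(=O)Nc2cc3nc(C4CCCCC4)[nH]c3cc2N(CC)CC)c1`, differs from compound 3 in one place: 3-vinylphenyl in place of 1-methylbutoxy on a carbonyl carbon.

The measured steps that bear on this change are those that swap the group on the carbonyl carbon between carbamate-type and aryl amide-type substituents: a step that the two limits leave unreadable from compound 2 to compound 3 and, in the same sense, a step that the two limits leave unreadable from compound 1 to compound 2. Neither gives a readable size, as both ends sit at the limit. Going by the values given here, nothing among the measured compounds suggests that a change on the carbonyl carbon moves this read-out off the limit. For compound 4 the expected step in this assay is a number no higher from compound 3 to compound 4 (the limit leaves the size open), that is, no step beyond the scatter. The estimate for compound 4 in this assay is 100 ug/mL, with a range from 50 ug/mL to 200 ug/mL, most likely again reported as a limit.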

Compound 4, half-maximal inhibitory concentration: > 100 ug/mL
Compound 4: no number, only a limit; the forecaster's own chance of this, stated with the estimate: 80%; the middle value sits exactly at the limit.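

In this assay, going by these compounds alone, compound 4 gives > 100 ug/mL as a limit, not a number, and no step to compound 4 from compound 1, compound 2 or compound 3 can be read. The compounds shown leave open whether any group on the carbonyl carbon moves this read-out off the limit.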